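Swapping a Propyl for a Hydroxy on a Cinnamamide

The compounds below may be only part of what the source reports. "The series", "measured", "known", "first", "only" and "open" are said of these compounds alone.

Measured so far in an assay on isolated protein for displacement of a labelled ligand from melanin-concentrating hormone receptor 1 (Homo sapiens); a higher number here means a weaker inhibitor, a lower number a stronger inhibitor:
- compound 1, `CCCc1ccc(/C=C/C(=O)Nc2ccc3nc(CCC)cc(N)c3c2)cc1`, 4 nM
- compound 2, `CCCc1cc(N)c2cc(NC(=O)CCc3ccccc3)ccc2n1`, 8300 nM
- compound 3, `CCCc1cc(NC2CC2)c2cc(NC(=O)/C=C/c3ccc(C(F)(F)F)cc3)ccc2n1`, 40 nM

Compound 1 gives the lowest number of the three. The nearest is compound 3, whose value lies beyond the usual scatter; compound 2 is the furthest away, again beyond the scatter. Among these three, compound 1 is therefore the strongest inhibitor in this assay.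

Compound 4, `CCCc1cc(N)c2cc(NC(=O)/C=C/c3ccc(O)cc3)ccc2n1`, is not yet measured. It differs from compound 1 in one place: hydroxy in place of propyl on an aromatic carbon. In words, a hydroxy stands in place of the propyl on the aromatic carbon of the outer ring, so that a 4-propylphenyl becomes a 4-hydroxyphenyl. Among the measured compounds shown here, no pair among the measured compounds shows this exact change, so the size of the step is not known from the numbers at hand.

Compound 1 is expected to be the stronger of the two, and the step of a 15-fold higher number from compound 1 to compound 4 (1.18 log units; beyond the scatter) is expected to go beyond the scatter toward a weaker inhibitor. For compound 4 the value in this assay is estimated at 60 nM, with a likely range from 15 nM to 300 nM.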

Compound 4, half-maximal inhibitory concentration: 1100 nM
For compound 4 the middle estimate is 18-fold (1.26 log units) below the measured one; the measured number lies above the stated range.
By their numbers in this assay, from the lowest: compound 1; then compound 3; then compound 4; then compound 2.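

Measured in this assay the change from 4-propylphenyl to 4-hydroxyphenyl comes to a 280-fold higher number from compound 1 to compound 4 (2.44 log units; beyond the scatter) and is a large step. The earlier compounds shown here could not show this, as no two of them differ in one place only. Here the size of a single change can be read for the first time, and it shows that the group on this aromatic carbon has a strong bearing on the result, with a hydroxy no match for a propyl in this series. No measurement shown explains the size of this step.

A single swap cannot separate the loss of the propyl from the arrival of the hydroxy. Going by these compounds, a methoxy, a plain hydrogen or a longer chain such as butyl on this same carbon remains open, and any of these would show how the value changes with the group placed here.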